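The source may report more compounds than this note shows. Statements on the series, on what has been measured and on what is new or still open speak of the compounds shown alone.

Four compounds built around a benzyl-substituted pyroglutamide were examined in an assay on HEK293 cells for inhibition of Ataxin-2 (Mus musculus), read by fluorescence and Amplex Red; on this read-out higher numbers stand for weaker inhibition and lower numbers for stronger inhibition. Compound 1 `O=C(O)c1ccc(COc2ccc(CNC(=O)[C@@H]3CCC(=O)N3Cc3ccccc3)cc2)cc1` carries a carboxy group on the outer aromatic ring. In this assay compound 1 gives 4500 nM. Compound 2 `O=C(NCc1ccc(OCc2ccc(-c3nn[nH]n3)cc2)cc1)[C@@H]1CCC(=O)N1Cc1ccccc1` differs from compound 1 by 2H-tetrazol-5-yl in place of carboxy on an aromatic carbon. For compound 2 this assay returns only the limit > 5000 nM, not a number. The step of an at least 1.1-fold higher number from compound 1 to compound 2 (0.04 log units; that floor lies within the scatter) therefore has a floor that lies within the usual scatter; what is known about it rests on (the limit of > 5000 nM in this assay, at which 2 of the 3 values shown sit), so its true size is open.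

Compound 3 `O=C(O)c1ccc(COc2ccc(CN3C(=O)CC[C@H]3C(=O)NCc3ccccc3)cc2)cc1` is made of the same atoms as compound 1, joined differently; the difference between the two cores is not broken down here. For compound 3 this assay again returns only the limit > 5000 nM.

Compound 4 `O=C(NCc1ccccc1)[C@@H]1CCC(=O)N1Cc1ccc(OCc2ccc(-c3nn[nH]n3)cc2)cc1` has not been measured. It differs from compound 3 by 2H-tetrazol-5-yl in place of carboxy on an aromatic carbon, the same change that separates compound 1 from compound 2. Since compound 3 already sits at the limit, and the step from compound 1 to compound 2 moved toward that limit an at least 1.1-fold higher number from compound 1 to compound 2 (0.04 log units; that floor lies within the scatter), compound 4 is expected to stay at or beyond it, so that the step that the limit leaves unreadable from compound 3 to compound 4 is an estimate rather than a measured change. Compound 4 is expected to give about 8000 nM in this assay, within a range from 4000 nM to 20000 nM, most likely reported as a limit.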

Compound 4, half-maximal inhibitory concentration: > 5000 nM
Compound 4 gave a limit, no number; the forecaster's own chance of this, stated with the estimate: 85%; the middle value is on the limit's open side.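

In this assay compound 4 gives > 5000 nM, which is a limit and not a number. Among these compounds, compound 3 also stands at a limit, so no step from compound 3 to compound 4 can be read, and what is known rests on one shared limit: the limit of > 5000 nM in this assay, at which 3 of the 4 values shown sit. The compounds shown leave open how far compound 2, compound 3 and compound 4 lie past that limit, and so what 2H-tetrazol-5-yl in place of carboxy does to inhibition.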